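The compounds below may be only part of what the source reports. "The series", "measured", "known", "first", "only" and "open" are said of these compounds alone.

Compound 1 `O=C(Nc1ccccc1)ON=C1CCC(c2ccccc2)CC1`; compound 2 `C/C(=N\OC(=O)Nc1ccccc1)c1cccc(-c2ccccc2)c1`.

In an assay for inhibition of Fatty-acid amide hydrolase 1 (Mus musculus), read by scintillation counting (on this read-out lower numbers stand for stronger inhibition and higher numbers for weaker inhibition), compound 1 gives > 50000 nM, which is a limit of the assay and not a number (the limit of > 50000 nM in this assay, at which 1 of the 2 values shown sits). In this assay, going by the values given here, compound 2 gives 69 nM, the only number measured so far. Compound 3 `COc1ccc(NC(=O)O/N=C(\C)c2cccc(-c3ccccc3)c2)cc1` differs from compound 2 by methoxy in place of hydrogen on an aromatic carbon, para to a large group. Among the compounds with values here, no measured step of this kind exists, so no change beyond the usual scatter is expected, in either direction. Compound 3 is expected to give 60 nM, estimated between 20 nM and 200 nM. The expected step is a 1.2-fold lower number from compound 2 to compound 3 (0.06 log units; within the scatter).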

Compound 3, half-maximal inhibitory concentration: 28 nM
Compound 3: the middle estimate sits 2.1-fold (0.33 log units) above what was measured, within the range that was stated.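

Placing methoxy on the aromatic carbon para to a large group, which turns phenyl into 4-methoxyphenyl, gives a 2.5-fold lower number from compound 2 to compound 3 (0.39 log units; beyond the scatter) in this assay. Going by these compounds alone, this is the first measured sign that this carbon can carry a substituent, and the number moves modestly but beyond the scatter. Nothing measured here gives a reason for the change.

A single step cannot show whether another group at this carbon, such as an amine, a carboxylic acid or a chlorine atom, would move the number the same way. On these data alone, whether methoxy would have the same effect on another carbon of this ring also stays open.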